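A few compounds are considered here, and "the series" means these few. Any claim that something is new, unique, unknown or untested is made for them only; others in the source may bear on it.

In a functional assay on NZB5 cells (Homo sapiens) for inhibition, read by thymidine incorporation, with a stated time of 5 days (a lower number here means a stronger inhibitor, a higher number a weaker inhibitor), compound 1 `Cc1ccc(C)c(S(=O)(=O)N(C)/N=C/c2cnn3ccc(C#N)cc23)c1` gives 2100 nM, compound 2 `Cc1ccc(Br)cc1S(=O)(=O)N(C)/N=C/c1cnn2ccc(C#N)cc12` gives 700 nM, and compound 3 `Cc1ccc(NC(=O)C(F)(F)F)cc1S(=O)(=O)N(C)/N=C/c1cnn2ccc(C#N)cc12` gives 2300 nM. The numbers show a 1.1-fold higher number from compound 1 to compound 3 (0.04 log units; within the scatter) and a 3.3-fold higher number from compound 2 to compound 3 (0.52 log units; beyond the scatter), so compound 3 matches one of the others and stands apart from the other. Compound 4 `Cc1ccccc1S(=O)(=O)N(C)/N=C/c1cnn2ccc(C#N)cc12` differs from compound 3 as follows: hydrogen in place of ((trifluoromethyl)carbonyl)amino on an aromatic carbon. The three measured compounds differ at this same aromatic carbon, and there the data also show a 3.0-fold lower number from compound 1 to compound 2 (0.48 log units; beyond the scatter). None of them carries hydrogen there, and these steps are modest or smaller, so they give no direction with any force. In this assay a step within the scatter is expected, leaning slightly lower, namely a 1.6-fold lower number from compound 3 to compound 4 (0.22 log units; within the scatter). For compound 4 the estimated value is 1400 nM, with an expected range of 500 nM to 4000 nM.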

Compound 4, half-maximal inhibitory concentration: > 20000 nM
Compound 4 gave a limit, no number; the forecaster's own chance of this, stated with the estimate: 3%; at least 14-fold (1.15 log units) between middle value and limit.
By their numbers in this assay, from the lowest: compound 2; then compounds 1 and 3 (each within the scatter of the next). At a limit, above all of these: compound 4.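

Compound 4 is read only as a limit in this assay: the limit of > 20000 nM in this assay, at which 1 of the 4 values shown sits. Among methyl, bromo and ((trifluoromethyl)carbonyl)amino at this aromatic carbon, para to a methyl group, the steps were modest or smaller, but hydrogen in their place gives an at least 8.6-fold higher number from compound 3 to compound 4 (0.93 log units; beyond the scatter), an at least 28-fold higher number from compound 2 to compound 4 (1.45 log units; beyond the scatter) and an at least 9.5-fold higher number from compound 1 to compound 4 (0.97 log units; beyond the scatter). For the compounds shown here, the position therefore matters more than the earlier compounds showed, since each of the three groups gives a clearly lower number than hydrogen.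

On these data alone, how far compound 4 lies past its limit stays unknown. As far as these compounds go, whether an amine, a methoxy group or a chlorine atom at this carbon would match compound 1, compound 2 or compound 3 also remains open.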